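The compounds below may be only part of what the source reports. "The series", "measured", "known", "first", "only" and "open" are said of these compounds alone.

Compound 1, `O=C(CSC(=S)N[C@H]1CCOC1=O)Nc1ccc(Cl)cc1`, gives only a limit of the assay, > 128000 nM, in a functional assay on EC9706 cells (Homo sapiens) for cytotoxicity, read by MTT assay, with a stated time of 72 h; a lower number here means a stronger inhibitor, a higher number a weaker inhibitor. Compound 2, `O=C(CSC(=S)N[C@H]1CCOC1=O)Nc1ccc(F)cc1`, gives 67100 nM.

Compound 2 therefore holds the only number shown; the other value is a limit. Among the measured compounds shown here, the single measured step, an at least 1.9-fold lower number from compound 1 to compound 2 (0.28 log units; that floor lies within the scatter), rests on a limit, (the limit of > 128000 nM in this assay, at which 1 of the 2 values shown sits), and its floor lies within the scatter. Compound 3, `CC(=O)c1ccc(NC(=O)CSC(=S)N[C@H]2CCOC2=O)cc1`, differs from compound 2 by acetyl in place of fluoro on an aromatic carbon. For the measured compounds named here, no measured step bears on an acetyl entering, so no direction is expected beyond the scatter. Compound 3 is estimated at 65000 nM, between 20000 nM and 200000 nM, meaning an expected step of a 1.0-fold lower number from compound 2 to compound 3 (0.01 log units; within the scatter).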

Compound 3, half-maximal inhibitory concentration: > 128000 nM
Compound 3: only a limit was reported (the forecaster's own chance of this, stated with the estimate: 35%); middle value at least 1.9-fold (0.29 log units) away from the limit.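

Acetyl in place of fluoro on this aromatic carbon gives an at least 1.9-fold higher number from compound 2 to compound 3 (0.28 log units; that floor lies within the scatter) in this assay, so a second group joins chloro in yielding no number. Compound 1 and compound 3 both give limits, and the step between them cannot be read. Of the three groups at this position, only fluoro gives a measured number, and the floor of its step to acetyl stays within the scatter: the limit of > 128000 nM in this assay, at which 2 of the 3 values shown sit.

Left open is whether an amine, a methoxy group or a carboxylic acid at this position would give a number in this assay. Going by these compounds, how far chloro and acetyl lie past the limit also remains open.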